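From a sulfo group to a methylsulfanyl chain

The source may hold more compounds than are shown below. What is called first, only, known or untested is meant among the compounds shown, and "the series" means these compounds.

Measured in a functional assay on MCF7 cells (Homo sapiens) for inhibition, read by MTT assay, with a stated time of 3 days; a lower number here means a stronger inhibitor, a higher number a weaker inhibitor:
- compound 1 `COc1cc(-c2nc3ccccc3s2)ccc1OCC(=O)NNC(=O)CN1CCC[C@H]1C(=O)O`: 840 nM
- compound 2 `CCOC(=O)[C@H](CS(=O)(=O)O)NCC(=O)NNC(=O)COc1ccc(-c2nc3ccccc3s2)cc1OC`: 1990 nM

Of these two compounds, compound 2 has the higher number and is therefore the weaker inhibitor. The next compound, compound 3 `CCOC(=O)[C@H](CCSC)NCC(=O)NNC(=O)COc1ccc(-c2nc3ccccc3s2)cc1OC`, differs from it in one place: (methylsulfanyl)methyl in place of sulfo on a saturated chain carbon, two bonds along the chain from an amine nitrogen and a carbonyl carbon. Read one bond further out, this is sulfomethyl changing to 2-(methylsulfanyl)ethyl.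

Going by the values given here, only one measured step bears on this change: a 2.4-fold higher number from compound 1 to compound 2 (0.37 log units; beyond the scatter). This modest step brought the sulfo group in, along with other changes, so it is only a loose guide. Among the compounds with values here, no measured step swaps the sulfo group alone. Since compound 1, which has no sulfo group, gives 840 nM, a modest move towards a lower number is expected in this assay. The expected step is a 1.4-fold lower number from compound 2 to compound 3 (0.15 log units; within the scatter). For compound 3 the estimated value is 1400 nM, with an expected range of 500 nM to 4000 nM.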

Compound 3, half-maximal inhibitory concentration: 1760 nM
Compound 3: the middle estimate sits 1.3-fold (0.10 log units) below what was measured, within the range that was stated.
By their numbers in this assay, from the lowest: compound 1; then compounds 3 and 2 (each within the scatter of the next).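

In this assay, putting (methylsulfanyl)methyl in place of sulfo at this saturated chain carbon gives a 1.1-fold lower number from compound 2 to compound 3 (0.05 log units; within the scatter), so this position accepts two very different groups with no change that can be told from the scatter. The sulfo group therefore cannot be what separates compound 2 from compound 1: without it, the gap remains, at a 2.1-fold higher number from compound 1 to compound 3 (0.32 log units; beyond the scatter). No measurement here explains why the two groups read alike.

The compounds shown leave open whether the gap to compound 1 follows from the ethoxycarbonyl group, which compounds 2 and 3 share, or from the open chain taking the place of the 2-carboxypyrrolidin-1-yl ring. A carboxylic acid in place of that ester on compound 3 would test the first, while an amine at the end of the side chain would probe this position further.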